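A few compounds are considered here, and "the series" means these few. Any claim that something is new, unique, unknown or untested is made for them only; others in the source may bear on it.

Compound 2 `CCCCN(O)C(=O)Nc1cc([C@@H]2CC[C@@H](c3cc(OC)c(OC)c(OC)c3)O2)cc(OC)c1OCCS(=O)(=O)c1ccc(Br)cc1` stands lowest of the two compounds measured in a functional assay on the whole organism for inhibition, with Mus musculus as the target, at a dose of 3 mg/kg (a lower number here means less inhibition, a higher number more inhibition at the dose given (going by the name of the read-out)), where compound 2 gives 29%. Compound 1 `CCCCN(O)C(=O)Nc1cc([C@@H]2CC[C@@H](c3cc(OC)c(OC)c(OC)c3)O2)cc(OC)c1OCCSc1ccc(Cl)cc1` gives 43% in this assay. Going by the values given here, the only measured step, a number 14 percentage points lower from compound 1 to compound 2 (beyond the scatter), moves in the opposite sense to the change now in view, as compound 3 `CCCCN(O)C(=O)Nc1cc([C@@H]2CC[C@@H](c3cc(OC)c(OC)c(OC)c3)O2)cc(OC)c1OCCSc1ccc(OC)cc1` differs from compound 2 by (4-methoxyphenyl)sulfanyl in place of (4-bromophenyl)sulfonyl on a saturated chain carbon, two bonds along the chain from an oxygen on an aromatic ring, so the sulfonyl gives way to a sulfanyl and the bromine to a methoxy group. A partial reversal of that lowering is expected, a modest rise, a number 11 percentage points higher from compound 2 to compound 3 (beyond the scatter). Compound 3 is therefore estimated to give 40% in this assay, within 25% to 55%.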

Compound 3, a percentage reported as inhibition, in the whole organism at one dose (the size of the read-out at that dose, not a potency): 24%
Beside the measured number, compound 3's estimate is 16 percentage points above it; the measured number lies below the stated range.
By their numbers in this assay, from the lowest: compounds 3 and 2 (each within the scatter of the next); then compound 1.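

In this assay, the exchange at this chain position gives a number 5 percentage points lower from compound 2 to compound 3 (within the scatter), so (4-methoxyphenyl)sulfanyl and (4-bromophenyl)sulfonyl are not separated here. With the sulfanyl kept, methoxy in place of chloro on the aromatic carbon gives a number 19 percentage points lower from compound 1 to compound 3 (beyond the scatter), showing that this single ring change alone moves the read-out beyond the scatter. Nothing available explains either step.

The sulfur oxidation state and the ring substituent change together between compound 2 and compound 3, so their separate contributions remain unresolved. Also open, from the compounds shown here alone, is how a sulfinyl link, or an amine on the aromatic ring, would read at this dose.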